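Swapping the aryl group on the shared core of compound 3

This account rests on a few compounds, and the source may have more. Where it says the series, first, only, none or still open, it means among the compounds named here.

Of the compounds shown here, three sharing one core have been measured. Compound 1 `NS(=O)(=O)c1cccc(-c2nc(C(c3ccc(F)cc3)c3ccc(F)cc3)sc2CC(=O)O)c1` gives 55% in an in vitro functional assay on HEK285-7 cells for antagonist activity at prostaglandin D2 receptor 2 (Homo sapiens), read by BRET and beta-arrestin recruitment; a lower number here means a smaller maximal response, a higher number a larger maximal response. Compound 2 `O=C(O)Cc1sc(C(c2ccc(F)cc2)c2ccc(F)cc2)nc1-c1cc(F)nc(F)c1` reaches 80%, and compound 3 `Cc1cc(-c2nc(C(c3ccc(F)cc3)c3ccc(F)cc3)sc2CC(=O)O)cnc1N` reaches 80%. Compound 3 thus stands level with compound 2 at the digits shown, the two together forming the highest pair of the three, while the step of a number 25 percentage points higher from compound 1 to compound 3 (beyond the scatter) lies beyond the scatter, as does a number 25 percentage points higher from compound 1 to compound 2 (beyond the scatter). The step of no change at the digits printed from compound 2 to compound 3 (within the scatter) shows that exchanging one six-membered aromatic ring with one hetero atom for another left the maximal response where it was.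

Compound 4 `O=C(O)Cc1sc(C(c2ccc(F)cc2)c2ccc(F)cc2)nc1-c1ccnc(O)c1` differs from compound 3 in one place: 2-hydroxypyridin-4-yl in place of 6-amino-5-methylpyridin-3-yl on an aromatic carbon. This is again an exchange of one six-membered aromatic ring with one hetero atom for another, so the closest guide is the step from compound 2 to compound 3, which stayed within the scatter; the two larger steps from compound 1 concern the loss of 3-sulfamoylphenyl and bear less directly on this change. Compound 4 is therefore expected to give about 75% in this assay , between 55% and 90%, meaning an expected step of a number 5 percentage points lower from compound 3 to compound 4 (within the scatter) that stays within the scatter.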

Compound 4, largest response reached (reported as efficacy), in percent of the reference or control that the assay uses: 60%
Beside the measured number, compound 4's estimate is 15 percentage points above it; the range from low to high includes it.
By their numbers in this assay, from the lowest: compounds 1 and 4 (each within the scatter of the next); then compounds 2 and 3 (each within the scatter of the next).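

Exchanging one six-membered aromatic ring with 1 hetero atom for another does not always leave the maximal response unchanged at this position: 2-hydroxypyridin-4-yl gives a number 20 percentage points lower from compound 3 to compound 4 (beyond the scatter) in place of 6-amino-5-methylpyridin-3-yl and a number 20 percentage points lower from compound 2 to compound 4 (beyond the scatter) in place of 2,6-difluoropyridin-4-yl, even though the first swap keeps the counts of hydrogen-bond donors and acceptors the same. Against 3-sulfamoylphenyl, the change reads a number 5 percentage points higher from compound 1 to compound 4 (within the scatter), so replacing that group with such a ring does not by itself bring the larger response seen for compound 2 and compound 3. Nothing available here accounts for these differences.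

On these data alone, what the hydroxyl group itself contributes stays open. So does whether a methoxy group on the same ring, or a plain pyridin-4-yl ring, would fall with compound 4 or with compound 2 and compound 3.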